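Dropping the chloro: compound 4 against compound 3

The source may report more compounds than this note shows. Statements on the series, on what has been measured and on what is new or still open speak of the compounds shown alone.

Measured compounds:
compound 1, `Cc1nnc(SCC(=O)N/N=c2/scc(-c3ccccc3)n2-c2ccccc2)s1`, 63.9%
compound 2, `O=C(CSc1nnnn1-c1ccccc1)N/N=c1/scc(-c2ccc(F)cc2)n1-c1ccccc1`, 43.7%
compound 3, `O=C(CSc1nnnn1-c1ccccc1)N/N=c1/scc(-c2ccc(Cl)cc2)n1-c1ccccc1`, 60%

All three numbers come from a functional assay on C6 cells (Rattus norvegicus) for cytotoxicity, read by MTT assay, with a stated time of 24 h, tested at 50 ug/mL; on this read-out higher numbers stand for a weaker effect at the one concentration tested and lower numbers for a stronger effect. Compound 3 stands second highest of the three values. Its nearest neighbour is compound 1, whose value lies within the scatter of that of compound 3, so no order between the two can be read. Among the measured compounds shown here, its furthest neighbour is compound 2, which sits beyond the scatter below compound 3; the only single-point step among the measured set is a number 16.3 percentage points higher from compound 2 to compound 3 (beyond the scatter).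

Compound 4, `O=C(CSc1nnnn1-c1ccccc1)N/N=c1/scc(-c2ccccc2)n1-c1ccccc1`, is not yet measured. Compared with compound 3 the change is hydrogen in place of chloro on an aromatic carbon. For the measured compounds named here, no measured step in this set swaps chloro for hydrogen, so the step from compound 2 to compound 3, a change between two halogens, bears on it only loosely. Compound 1, which carries an unsubstituted phenyl together with a different thioether part, gives a value within the scatter of compound 3, which hints that the unsubstituted phenyl need not depart far.

Compound 4 is therefore expected to show a step of a number 2 percentage points lower from compound 3 to compound 4 (within the scatter) in this assay, most likely within the scatter. The estimate for compound 4 is 58%, with a range from 40% to 76%.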

Compound 4, a percentage reported as activity, at one concentration (the size of the read-out at that concentration, not a potency): 36.7%
Estimate against measurement, compound 4: 21.3 percentage points above, and the stated range ends above it.
By their numbers in this assay, from the lowest: compounds 4 and 2 (each within the scatter of the next); then compounds 3 and 1 (each within the scatter of the next).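

Taking the chloro off the 4-chlorophenyl gives a number 23.3 percentage points lower from compound 3 to compound 4 (beyond the scatter) in this assay, which means that on this aromatic carbon, para to a large group, the chloro goes with a weaker effect at the one concentration tested. Hydrogen and fluoro cannot be told apart here, with a number 7 percentage points lower from compound 2 to compound 4 (within the scatter) as the printed step, so among the three substituents at this position only the chloro stands apart, and the change is not a steady trend from hydrogen through fluoro to chloro. Among the compounds shown here, with the unsubstituted phenyl held fixed, the group on the sulfur also counts, since a number 27.2 percentage points lower from compound 1 to compound 4 (beyond the scatter) in the same assay, a comparison that no earlier pair allowed.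

Nothing at hand explains why the chloro alone separates from hydrogen and fluoro. Going by these compounds, it remains open whether a bromo or a methoxy on the same carbon would follow the chloro or the hydrogen, and whether the chloro step would recur with the 5-methyl-1,3,4-thiadiazol-2-yl on the sulfur in place of the 1-phenyl-1H-tetrazol-5-yl.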